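The compounds below may be only part of what the source reports. "The series", "measured", "known", "first", "only" and "open" are said of these compounds alone.

In a functional assay on Vero cells (Chlorocebus sabaeus) for cytotoxicity (on this read-out lower numbers stand for stronger inhibition and higher numbers for weaker inhibition), compound 1 (`COc1ccc(-c2cncc(-c3cc(NCCCn4ccnc4)nc(C)n3)c2)cc1`) has no usable number: its entry reads "not determined" (no result reported) and offers no starting point. Compound 2 (`O=C(NCc1ccncc1)c1ccc(-c2cnn(Cc3ccccc3)c2)nc1`) is in the same position, with "not determined" (no result reported) as its entry. The one measured figure belongs to compound 3 (`c1ccc(-c2nc(NCCCn3ccnc3)cc(-c3cccnc3)n2)cc1`), which gives 40700 nM as its result. Compound 4 (`Cc1nc(NCCCn2ccnc2)cc(-c2cncc(-c3ccc(F)cc3)c2)n1`) differs from compound 1 by a single swap: fluoro in place of methoxy on an aromatic carbon (fluoro in place of methoxy on an aromatic carbon, so 4-methoxyphenyl becomes 4-fluorophenyl). Going by the values given here, no measured pair shows the size of such a swap, so no step beyond the usual scatter is expected in this assay and no direction can be named. The expectation therefore rests on compound 3 at 40700 nM as the only anchor. Compound 4 is expected near 30000 nM with an estimated range from 9000 nM to 90000 nM in this measurement.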

Compound 4, half-maximal inhibitory concentration: 41200 nM
Estimate against measurement, compound 4: 1.4-fold (0.14 log units) below; the range from low to high includes it.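

Compound 1 has no single number to set against compound 4, so no step can be read for the change from 4-methoxyphenyl to 4-fluorophenyl. No measured evidence on cause is available here. Going by these compounds, the size and direction of this swap remain open.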